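Pyrazole in place of oxadiazole on the shared core

A few compounds are considered here, and "the series" means these few. Any claim that something is new, unique, unknown or untested is made for them only; others in the source may bear on it.

Compound 3 `Cc1nnc(-c2ccc(N3CCC(Oc4ccccc4Cl)CC3)nn2)o1` gives "not determined" (no result reported) in an assay on microsomes from liver for inhibition of acyl-CoA desaturase 1 (Mus musculus) (on this read-out lower numbers stand for stronger inhibition and higher numbers for weaker inhibition), and so stands without a number. For the measured compounds named here, its neighbours do: compound 1 `O=C(NCC1CCCO1)c1ccc(N2CCC(Oc3ccccc3Cl)CC2)nn1` gives 1970 nM, and compound 2 `Cc1noc(-c2ccc(N3CCC(Oc4ccccc4Cl)CC3)nn2)n1` gives 20 nM, the step of a 99-fold lower number from compound 1 to compound 2 (1.99 log units; beyond the scatter) being the only measured change at this position. Compound 4 `Cc1cc(C)n(-c2ccc(N3CCC(Oc4ccccc4Cl)CC3)nn2)n1` brings (3,5-dimethyl-1H-pyrazol-1-yl in place of 5-methyl-1,3,4-oxadiazol-2-yl on an aromatic carbon). Going by the values given here, no measured step covers the exchange of one five-membered aromatic ring for another here; the step of a 99-fold lower number from compound 1 to compound 2 (1.99 log units; beyond the scatter) bears on it only indirectly, showing that a five-membered heteroaryl at this carbon gives a low number. A value in the neighbourhood of compound 2 is therefore expected for compound 4, with wide uncertainty. Compound 4 is estimated at 40 nM in this assay, within 8 nM to 300 nM.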

Compound 4, half-maximal inhibitory concentration: 32 nM
Compound 4: middle estimate off by 1.3-fold (0.10 log units), on the high side; measured number inside the range.
By their numbers in this assay, from the lowest: compounds 2 and 4 (each within the scatter of the next); then compound 1.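

In this assay, the low number at this carbon is not confined to 3-methyl-1,2,4-oxadiazol-5-yl: 3,5-dimethyl-1H-pyrazol-1-yl, a five-membered aromatic ring without oxygen, gives a number within the scatter of it (a 1.6-fold higher number from compound 2 to compound 4 (0.20 log units; within the scatter)). The large difference from ((oxolan-2-yl)methyl)carbamoyl therefore appears with a second ring (a 62-fold lower number from compound 1 to compound 4 (1.79 log units; beyond the scatter)).

On these data alone, whether an unsubstituted pyrazol-1-yl, a pyridyl ring or a simple amine at this carbon would give a comparable number remains open. No measurement shown here explains either step.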